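This account rests on a few compounds, and the source may have more. Where it says the series, first, only, none or still open, it means among the compounds named here.

The series shares one core, an amide whose carbonyl carbon carries a variable aryl group. Compound 1 `O=C(Nc1ccc(Cl)c(-c2nnc3c(Cl)cccn23)c1)c1ccccn1` carries pyridin-2-yl there, and in a functional assay on MCF7 cells (Homo sapiens) for antiproliferative activity, read by MTT assay, with a stated time of 72 h (a higher number here means a weaker inhibitor, a lower number a stronger inhibitor), compound 1 gives 96400 nM. Compound 2 `O=C(Nc1ccc(Cl)c(-c2nnc3c(Cl)cccn23)c1)c1ccc(Cl)cc1` carries 4-chlorophenyl, and in this assay compound 2 gives 58400 nM. Compound 3 `Cc1cc(Cl)ccc1C(=O)Nc1ccc(Cl)c(-c2nnc3c(Cl)cccn23)c1` carries 4-chloro-2-methylphenyl. In this assay compound 3 reaches only a limit, > 100000 nM, and that is the limit of > 100000 nM in this assay, at which 1 of the 3 values shown sits. Compound 3 thus stands only as a floor, and its steps from the other two compounds are floors that lie within the scatter: an at least 1.0-fold higher number from compound 1 to compound 3 (0.01 log units; that floor lies within the scatter) and an at least 1.7-fold higher number from compound 2 to compound 3 (0.23 log units; that floor lies within the scatter). The step of a 1.7-fold lower number from compound 1 to compound 2 (0.22 log units; within the scatter) lies within the scatter as well, so the three measured compounds cannot be ordered against one another.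

Compound 4 `O=C(Nc1ccc(Cl)c(-c2nnc3c(Cl)cccn23)c1)c1ccon1` differs from compound 3 in one place: 1,2-oxazol-3-yl in place of 4-chloro-2-methylphenyl on a carbonyl carbon. The measured steps that bear on such a swap of the group on the carbonyl carbon are a 1.7-fold lower number from compound 1 to compound 2 (0.22 log units; within the scatter) and an at least 1.0-fold higher number from compound 1 to compound 3 (0.01 log units; that floor lies within the scatter), both within the scatter, so no movement beyond the scatter is expected for compound 4 in this assay. The estimate for compound 4 is 100000 nM, with a range from 40000 nM to 250000 nM, which means an expected step of a number no higher from compound 3 to compound 4 (the limit leaves the size open).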

Compound 4, half-maximal inhibitory concentration: > 100000 nM
Compound 4 was reported as a limit; the forecaster's own chance of this, stated with the estimate: 55%; the middle value sits exactly at the limit.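

In this assay compound 4 gives > 100000 nM, which is a limit of the assay and not a number, so replacing 4-chloro-2-methylphenyl with the smaller 1,2-oxazol-3-yl, with 5 heavy atoms in place of 8 and 2 hydrogen-bond acceptors in place of 0, brought no reading inside the range of the assay. Its steps from the two compounds with numbers, an at least 1.7-fold higher number from compound 2 to compound 4 (0.23 log units; that floor lies within the scatter) and an at least 1.0-fold higher number from compound 1 to compound 4 (0.01 log units; that floor lies within the scatter), are floors that lie within the scatter, so compound 4 cannot be ordered against either, and its step from compound 3 cannot be read. The place on the carbonyl carbon now holds two different ring types at the same limit, a six-membered aromatic ring of carbon only and a five-membered aromatic ring with 2 hetero atoms: the limit of > 100000 nM in this assay, at which 2 of the 4 values shown sit.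

On these data alone, whether any group on this carbonyl carbon can move the number beyond the scatter stays open, since all steps among the four compounds are floors, unreadable or within the scatter. As far as these compounds go, how a non-aromatic group there, such as a piperidine, a carboxylic acid or a longer alkyl chain, would read in this assay also remains open.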